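The source may hold more compounds than are shown below. What is called first, only, known or untested is meant among the compounds shown, and "the series" means these compounds.

Measured in a functional assay (aorta) with Rattus norvegicus as the target, in the presence of a further agent that is not named here; on this read-out higher numbers stand for an effect only at larger amounts of compound and lower numbers for an effect already at smaller amounts:
- compound 1 `COC(=O)C1=C(C)N=C(C)/C(=C(/O)OC)C1c1ccccc1OCCO[N+](=O)[O-]`: 56 nM
- compound 2 `COC(=O)C1=C(C)N=C(C)/C(=C(/O)OC)C1c1cccc(OCCO[N+](=O)[O-])c1`: 750 nM
- compound 3 `COC(=O)C1=C(C)N=C(C)/C(=C(/O)OC)C1c1cccc(OCc2no[n+]([O-])c2C)c1`: 500 nM

Of these three numbers, compound 1 gives 56 nM, clearly lower than the other two and beyond the scatter from both. Compound 3, at 500 nM, stands with compound 2 at the upper end, and the two cannot be told apart.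

The open question is compound 4 `COC(=O)C1=C(C)N=C(C)/C(=C(/O)OC)C1c1cccc(OCc2c(C(N)=O)no[n+]2[O-])c1`, which differs from compound 3 in one place: a group of 9 heavy atoms (3 carbon, 3 nitrogen, 3 oxygen; one five-membered aromatic ring with 3 hetero atoms) in place of a group of 7 heavy atoms (3 carbon, 2 nitrogen, 2 oxygen; one five-membered aromatic ring with 3 hetero atoms), on a saturated chain carbon bound to an oxygen on an aromatic ring. Among the measured compounds shown here, only one measured step bears on this place, namely a 1.5-fold lower number from compound 2 to compound 3 (0.18 log units; within the scatter). That step replaced a group without a ring by one with a five-membered aromatic ring with 3 hetero atoms, and it stayed within the scatter. No measured compound carries the entering group, so the size of this change in this assay is not shown directly.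

Resting on that single small step, no shift beyond the scatter is expected, though the uncertainty is wide. The expected change is a 1.4-fold lower number from compound 3 to compound 4 (0.15 log units; within the scatter). For compound 4 the estimated value is 350 nM, with an expected range from 80 nM to 1500 nM.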

Compound 4, half-maximal effective concentration: 1200 nM
Compound 4: middle estimate off by 3.4-fold (0.54 log units), on the low side; low and high end bracket the measured number.
By their numbers in this assay, from the lowest: compound 1; then compounds 3, 2 and 4 (each within the scatter of the next, the first and the last beyond it).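

In this assay, among the compounds shown here, the earlier compounds showed only that a group with a five-membered aromatic ring with 3 hetero atoms could replace a group without a ring, with no change beyond the scatter. The new result shows that the number can still move when one such ring-bearing group replaces another on the saturated chain carbon bound to an oxygen on an aromatic ring: a 2.4-fold higher number from compound 3 to compound 4 (0.38 log units; beyond the scatter), with the entering group being the larger and carrying 1 hydrogen-bond donor where the leaving group has 0. The effect is modest and depends on the comparison, since a 1.6-fold higher number from compound 2 to compound 4 (0.20 log units; within the scatter), and nothing given here accounts for either step.

The compounds shown leave open whether the carboxamide of the entering group is what goes with the higher number, or whether a nitrile or a carboxylic acid on the same ring would give a similar value. They also leave open how a longer chain carrying either ring group would read out, and whether these ring groups would give the same order of numbers on the core of compound 1.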